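A few compounds are considered here, and "the series" means these few. Any claim that something is new, unique, unknown or untested is made for them only; others in the source may bear on it.

Series notes. In a functional assay on thoracic aorta for antagonist activity at thromboxane A2 receptor (Rattus norvegicus) (a lower number here means a stronger inhibitor, a higher number a weaker inhibitor), compound 2 `CC(C)c1ccc2c(CCCCS(=O)(=O)Nc3ccccc3)cc(S(=O)(=O)O)c-2cc1` gives 1500 nM; compound 1 `CC(C)c1ccc2c(CCCCS(=O)(=O)Nc3ccc(Cl)cc3)cc(C(=O)O)c-2cc1` gives 2600 nM in this assay, and the gap between the two numbers lies within the scatter, so neither stands apart from the other. Compound 3 `CC(C)c1ccc2c(CCCCS(=O)(=O)Nc3ccc(Cl)cc3)cc(S(=O)(=O)O)c-2cc1` is not yet measured in this assay. Compound 3 differs from compound 2 by chloro in place of hydrogen on an aromatic carbon. Within the data shown here, no measured pair shows this change on its own, so the expected step from compound 2 to compound 3 is set near zero, a 1.2-fold higher number from compound 2 to compound 3 (0.08 log units; within the scatter), with no direction beyond the scatter. The estimate for compound 3 in this assay is 1800 nM, within 700 nM to 5000 nM.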

Compound 3, half-maximal inhibitory concentration: 220 nM
For compound 3 the middle estimate is 8.2-fold (0.91 log units) above the measured one; the measured number lies below the stated range.
By their numbers in this assay, from the lowest: compound 3; then compounds 2 and 1 (each within the scatter of the next).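

In this assay, among these compounds, the change from anilino to (4-chlorophenyl)amino, with sulfo held fixed, gives a 6.8-fold lower number from compound 2 to compound 3 (0.83 log units; beyond the scatter) and is the first single-place step read at this position. With the chloro held fixed, sulfo in place of carboxy gives a 12-fold lower number from compound 1 to compound 3 (1.07 log units; beyond the scatter), so the acid-bearing position also matters in the presence of the chloro. Nothing measured on these compounds accounts for either step. On these data alone, whether fluoro, bromo or methyl in place of chloro gives a comparable step remains open, as does whether the chloro step holds alongside carboxy.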